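Two Limits and a Third Analogue Ahead

The source may hold more compounds than are shown below. What is called first, only, known or untested is meant among the compounds shown, and "the series" means these compounds.

Compound 1, `O=C(Cn1cc(-c2ccc(F)cc2)nn1)Nc1nc2ccccc2s1`: in a functional assay on BMDM cells (Mus musculus, strain C57BL/6) for inhibition, with a stated time of 2 days (a higher number here means a weaker inhibitor, a lower number a stronger inhibitor), compound 1 gives > 30000 nM, which is a limit of the assay and not a number.
Compound 2, `N#Cc1ccc(-c2cn(CC(=O)Nc3nc4ccccc4s3)nn2)cc1`: in this assay compound 2 gives > 30000 nM, again a limit of the assay rather than a measured number.

Compound 2 therefore stands only at a limit, and compound 1 sits at the same one, as the limit of > 30000 nM in this assay, at which 2 of the 2 values shown sit, records. Going by the values given here, the single measured step, a step that the two limits leave unreadable from compound 1 to compound 2, is consequently unreadable in size, and nothing can be said about whether cyano in place of fluoro helped or hurt.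

The unmeasured compound 3, `COC(=O)c1ccc(-c2cn(CC(=O)Nc3nc4ccccc4s3)nn2)cc1`, differs from compound 2 by methoxycarbonyl in place of cyano on an aromatic carbon. Among the compounds with values here, no measured step involves a methoxycarbonyl group, and the only step at hand gives no usable size, so there is no basis for expecting a step in either direction beyond the scatter in this assay. With both neighbours at the limit, the expected step that the limit leaves unreadable from compound 2 to compound 3 is simply one that keeps compound 3 in the same region. Compound 3 is thus estimated at 40000 nM, within a range from 15000 nM to 150000 nM, and the most likely result is that the assay again reports only a limit.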

Compound 3, half-maximal inhibitory concentration: > 30000 nM
Compound 3: no number, only a limit (the forecaster's own chance of this, stated with the estimate: 80%); the middle value is on the limit's open side.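

No step can be read among compound 1, compound 2 and compound 3, as all three stop at the same limit of the assay, not at a number: the limit of > 30000 nM in this assay, at which 3 of the 3 values shown sit.

The compounds shown leave open whether fluoro, cyano and methoxycarbonyl differ at all in their effect on inhibition, and what change to these compounds would give a measurable value.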